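Swapping pentyl for a shorter chain on the amide

The source may hold more compounds than are shown below. What is called first, only, known or untested is meant among the compounds shown, and "the series" means these compounds.

- Compound 1 `CCCCCCCCc1ccc(CCC(CO)(CO)NC(=O)CCCCC)c2ccccc12` gives 20300 nM in the measurements below
- Compound 2 `CCCCCCCOc1ccc(CCC(CO)(CO)NC(=O)CCCCC)c2ccccc12` gives 21900 nM in the same measurements

Among the measured compounds shown here, in a functional assay on HT-29 cells (Homo sapiens) for antiproliferative activity, read by sulforhodamine B assay, with a stated time of 72 h (on this read-out lower numbers stand for stronger inhibition and higher numbers for weaker inhibition), compound 2 stands level with compound 1, the only other compound measured. Heptyloxy in place of octyl on an aromatic carbon gives a 1.1-fold higher number from compound 1 to compound 2 (0.03 log units; within the scatter) and so separates the two by no real margin. Compound 3 `C/C=C/C(=O)NC(CO)(CO)CCc1ccc(OCCCCCCC)c2ccccc12` keeps the heptyloxy group of compound 2 but carries prop-1-en-1-yl in place of pentyl on a carbonyl carbon. For the measured compounds named here, the only measured step, a 1.1-fold higher number from compound 1 to compound 2 (0.03 log units; within the scatter) at an aromatic carbon, does not touch this place. It therefore offers no direction, and no shift beyond the scatter is expected in this assay though the uncertainty stays wide. The expected step is a 1.1-fold lower number from compound 2 to compound 3 (0.04 log units; within the scatter) on this estimate. Compound 3 is estimated at 20000 nM with an expected range from 8000 nM to 50000 nM in this measurement.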

Compound 3, half-maximal inhibitory concentration: 36400 nM
The estimate for compound 3 lay 1.8-fold (0.26 log units) below the measured number; measured number inside the range.
By their numbers in this assay, from the lowest: compounds 1, 2 and 3 (each within the scatter of the next).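

Among the compounds shown here, this step is the first look at the amide end of the molecule. In this assay, prop-1-en-1-yl in place of pentyl on a carbonyl carbon gives a 1.7-fold higher number from compound 2 to compound 3 (0.22 log units; within the scatter) and stays within the scatter, so this change does not separate compound 3 from compound 2. Removing two carbons from the chain and adding a double bond outside aromatic rings therefore leaves the read-out without a real shift, and no measurement shown here offers an explanation for the result.

The compounds shown change chain length and the double bond together, so the contribution of each remains open. From the compounds shown here alone, how a saturated propyl group, a longer chain such as nonyl, or a chain ending in an amine would read at this carbonyl also remains unknown.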